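The source may report more compounds than this note shows. Statements on the series, on what has been measured and on what is new or still open speak of the compounds shown alone.

Measured so far:
compound 1, `O=c1c(O)cccn1Cc1ccccc1` — in an ADME assay on THP-1 cells (Homo sapiens) for cytotoxicity, read by resazurin assay, with a stated time of 48 h (on this read-out lower numbers stand for stronger inhibition and higher numbers for weaker inhibition), compound 1 gives > 10 ug/mL, a limit of the assay rather than a number.
compound 2, `N#Cc1ccccc1-c1ccc(Cn2cccc(O)c2=S)cc1` — in this assay compound 2 gives > 10 ug/mL, likewise a limit.

Compound 1 therefore stands at the edge of what this assay reports, and nothing more precise is known of it: the limit of > 10 ug/mL in this assay, at which 2 of the 2 values shown sit. Compound 3, `Cc1ccc(-c2ccc(Cn3cccc(O)c3=O)cc2)cc1`, has not yet been measured in this assay. It differs from compound 1 in one place: 4-methylphenyl in place of hydrogen on an aromatic carbon. For the measured compounds named here, no step between two measured compounds is available, so the effect of such a change cannot be read from data here; compound 2 offers only a second limit, not a number. The step from compound 1 to compound 3 is expected to be no larger than the usual scatter, if any, in the direction of slightly stronger inhibition: a step that the limit leaves unreadable from compound 1 to compound 3. Compound 3 is thus estimated to give 15 ug/mL, most likely again as a limit, in a range from 5 ug/mL to 40 ug/mL.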

Compound 3, half-maximal inhibitory concentration: > 10 ug/mL
Compound 3: only a limit was reported; the forecaster's own chance of this, stated with the estimate: 70%; the middle value does not contradict the limit.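

For the compounds shown here, compound 3, like compound 1, is reported only as a limit, so no step between the two can be read: the limit of > 10 ug/mL in this assay, at which 3 of the 3 values shown sit. The compounds shown leave open what number any of them would give in this assay, and whether 4-methylphenyl in place of hydrogen shifts it at all.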